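The compounds below may be only part of what the source reports. "The series", "measured", "known", "first", "only" and "open" are said of these compounds alone.

Within the data shown here, in a functional assay on HT-29 cells (Homo sapiens) for inhibition, read by CellTiter-Glo, with a stated time of 72 h (on this read-out higher numbers stand for lower toxicity in this test and lower numbers for higher toxicity in this test), compound 1 `CC1=C(CC(=O)N(C)CCN(C)S(=O)(=O)c2ccccc2)c2cc(F)ccc2/C1=C\c1ccc([S+](C)[O-])cc1` gives 6090 nM and compound 2 `CC1=C(CC(=O)N(C)CCN(C)S(=O)(=O)c2ccc(C)cc2)c2cc(F)ccc2/C1=C\c1ccc([S+](C)[O-])cc1` gives 6180 nM, so compound 2 stands within the scatter of the only other measured compound. Compound 3 `CC1=C(CC(=O)N(C)CCN(C)S(=O)(=O)c2cccc3ccccc23)c2cc(F)ccc2/C1=C\c1ccc([S+](C)[O-])cc1` differs from compound 2 as follows: naphthalen-1-yl in place of 4-methylphenyl on a sulfonyl sulfur. Among the measured compounds shown here, only one measured step bears on this change, a 1.0-fold higher number from compound 1 to compound 2 (0.01 log units; within the scatter), which replaced hydrogen with methyl on an aromatic carbon of the same group. For the measured compounds named here, no measured compound carries naphthalen-1-yl, so the evidence is thin. The expected result is a 1.1-fold lower number from compound 2 to compound 3 (0.05 log units; within the scatter), with no shift beyond the scatter anticipated in this assay. For compound 3, the estimated value is 5500 nM, with an expected range of 2200 nM to 13000 nM.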

Compound 3, half-maximal cytotoxic concentration: 3990 nM
Compound 3: middle estimate off by 1.4-fold (0.14 log units), on the high side; measured number inside the range.
By their numbers in this assay, from the lowest: compounds 3, 1 and 2 (each within the scatter of the next).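

At the sulfonyl sulfur, the change to naphthalen-1-yl, with 2 six-membered aromatic rings, gives a 1.5-fold lower number from compound 2 to compound 3 (0.19 log units; within the scatter) and a 1.5-fold lower number from compound 1 to compound 3 (0.18 log units; within the scatter) in this assay and so stays within the scatter. The earlier pair differed only by a methyl on the aromatic ring, whereas this larger all-carbon group also leaves the number within the scatter. No measurement at hand accounts for these numbers. The compounds shown leave open whether an aromatic ring carrying an amine or a carboxylic acid would move the number beyond the scatter. They also leave open how naphthalen-2-yl would read at this place.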